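Inverting the chain stereocentre of compound 2

The source may hold more compounds than are shown below. What is called first, only, known or untested is meant among the compounds shown, and "the series" means these compounds.

Compound 1 `CCCCc1oc2ccccc2c1C(=O)c1ccc(OCCCC(=O)N2CCCC2)cc1`: 48700 nM
Compound 2 `CCCCc1oc2ccccc2c1C(=O)c1ccc(OCCCC(=O)N[C@@H](C)c2ccccc2)cc1`: > 50000 nM

In a functional assay on MDA-MB-231 cells (Homo sapiens) for antiproliferative activity, read by MTT assay, with a stated time of 24 h (on this read-out lower numbers stand for stronger inhibition and higher numbers for weaker inhibition), compound 2 gives > 50000 nM as a limit of the assay and not a number. The change to compound 3 `CCCCc1oc2ccccc2c1C(=O)c1ccc(OCCCC(=O)N[C@H](C)c2ccccc2)cc1` is the two compounds have the same atoms and bonds and differ only in configuration as drawn: 1 of 1 stereo elements differ; a stereocentre at a saturated chain carbon is drawn S in compound 2 and R in compound 3 with a saturated chain carbon drawn S in compound 2 and R in compound 3. Among the compounds with values here, the only measured step of an at least 1.0-fold higher number from compound 1 to compound 2 (0.01 log units; that floor lies within the scatter) replaces pyrrolidin-1-yl with (1-phenylethyl)amino on a carbonyl carbon and says nothing about configuration. The anchor for compound 2 is the limit of > 50000 nM in this assay, at which 1 of the 2 values shown sits, and no step beyond the scatter is expected in this assay from this inversion. An expected step that the limit leaves unreadable from compound 2 to compound 3 would follow. Compound 3 is estimated at 60000 nM within 25000 nM to 150000 nM as an expectation only.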

Compound 3, half-maximal inhibitory concentration: > 50000 nM
Compound 3: no number, only a limit (the forecaster's own chance of this, stated with the estimate: 65%); the middle value lies beyond the limit too.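

In this assay compound 3 gives > 50000 nM, a limit of the assay and not a number. Compound 2 ends at such a limit too, so the step between the two cannot be read and inverting the chain stereocentre gives no readable difference: the limit of > 50000 nM in this assay, at which 2 of the 3 values shown sit.

With the R configuration, the comparison with the pyrrolidin-1-yl amide gives an at least 1.0-fold higher number from compound 1 to compound 3 (0.01 log units; that floor lies within the scatter).

Still open, going by these compounds, is how far either configuration lies past the limit. Also open, on these data alone, is how a morpholin-4-yl group or a carboxylic acid on that carbonyl carbon would read in this assay.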